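The source may report more compounds than this note shows. Statements on the series, on what has been measured and on what is new or still open speak of the compounds shown alone.

In an ADME assay on L02 cells (Homo sapiens) for cytotoxicity, read by MTT assay, with a stated time of 24 h (on this read-out lower numbers stand for stronger inhibition and higher numbers for weaker inhibition), compound 3 (`O=C1/C(=C/c2ccncc2)CN(S(=O)(=O)c2ccc(C(F)(F)F)cc2)C/C1=C\c1ccccc1C(F)(F)F`) gives 13800 nM. This lies within the scatter of the other two measured compounds: compound 1 (`O=C1/C(=C/c2cccnc2)CN(S(=O)(=O)c2ccc(Br)cc2)C/C1=C\c1ccccc1C(F)(F)F`) gives 13300 nM and compound 2 (`Cc1ccc(S(=O)(=O)N2C/C(=C\c3ccncc3)C(=O)/C(=C/c3ccccc3C(F)(F)F)C2)cc1`) gives 12800 nM. Compound 4 (`O=C1/C(=C/c2ccncc2)CN(S(=O)(=O)c2ccc(Br)cc2)C/C1=C\c1ccccc1C(F)(F)F`) differs from compound 3 by one change, bromo in place of trifluoromethyl on an aromatic carbon. For the measured compounds named here, one measured step bears on this change, a 1.1-fold higher number from compound 2 to compound 3 (0.03 log units; within the scatter), where trifluoromethyl replaced methyl on an aromatic carbon. Going by the values given here, with only that step to go on, no change beyond the scatter is expected in this assay. The expected step is a 1.0-fold lower number from compound 3 to compound 4 (0.02 log units; within the scatter). Compound 4 is estimated at 13300 nM, with an expected range of 8000 nM to 21000 nM.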

Compound 4, half-maximal inhibitory concentration: 12600 nM
Estimate against measurement, compound 4: 1.1-fold (0.02 log units) above; measured number inside the range.
By their numbers in this assay, from the lowest: compounds 4, 2, 1 and 3 (each within the scatter of the next).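

In this assay bromo on this aromatic carbon reads no differently from trifluoromethyl or methyl, with a 1.1-fold lower number from compound 3 to compound 4 (0.04 log units; within the scatter) and a 1.0-fold lower number from compound 2 to compound 4 (0.01 log units; within the scatter) as the two direct swaps. For the compounds shown here, three groups at this place now sit within the scatter of one another, where the earlier compounds offered only two. The change in the other place also stays within the scatter, with a 1.1-fold lower number from compound 1 to compound 4 (0.02 log units; within the scatter) for pyridin-4-yl in place of pyridin-3-yl in the bromo compounds. On these data alone, whether an amine or a carboxylic acid on this carbon would shift the number remains open. Nothing given here accounts for this flat reading.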